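Reintroducing a nitro group on the anilino ring

The source may hold more compounds than are shown below. What is called first, only, known or untested is meant among the compounds shown, and "the series" means these compounds.

Measured so far:
compound 1, `Cc1cc(Nc2cc(N3CCN(C)CC3)nc(Nc3cccc([N+](=O)[O-])c3)n2)n[nH]1`: 138 nM
compound 2, `COc1cccc(Nc2nc(Nc3cc(C)[nH]n3)cc(N3CCN(C)CC3)n2)c1`: 509 nM

Among the measured compounds shown here, in a functional assay on K562 cells (Homo sapiens) for antiproliferative activity, read by CCK-8 assay, with a stated time of 72 h (a higher number here means a weaker inhibitor, a lower number a stronger inhibitor), compound 2 gives 509 nM, the highest number of the two measured values, with compound 1 at 138 nM as its only neighbour. For the measured compounds named here, the single measured step, a 3.7-fold higher number from compound 1 to compound 2 (0.57 log units; beyond the scatter), shows that exchanging nitro for methoxy cost potency. Compound 3, `Cc1cc(Nc2cc(N3CCN(C)CC3)nc(Nc3ccc([N+](=O)[O-])cc3)n2)n[nH]1`, has not yet been measured. Its change from compound 2 is 4-nitrophenyl in place of 3-methoxyphenyl on a nitrogen on an aromatic ring. This step bears on the earlier one only in part: it brings a nitro group back, though as 4-nitrophenyl rather than the 3-nitrophenyl of compound 1, so the reversal of a 3.7-fold higher number from compound 1 to compound 2 (0.57 log units; beyond the scatter) need not be exact. The expected step is therefore a decrease, roughly a 2.8-fold lower number from compound 2 to compound 3 (0.45 log units; beyond the scatter), toward the region of compound 1. Compound 3 is estimated at 180 nM, with a range of 60 nM to 550 nM.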

Compound 3, half-maximal inhibitory concentration: 137 nM
Compound 3: middle estimate off by 1.3-fold (0.12 log units), on the high side; measured number inside the range.
By their numbers in this assay, from the lowest: compounds 3 and 1 (each within the scatter of the next); then compound 2.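

Compound 3 shows that the nitro group can sit elsewhere on the anilino ring without loss: in this assay, 4-nitrophenyl in place of 3-methoxyphenyl gives a 3.7-fold lower number from compound 2 to compound 3 (0.57 log units; beyond the scatter), a step that changes both the group and its place on the ring. Setting 4-nitrophenyl against 3-nitrophenyl gives a 1.0-fold lower number from compound 1 to compound 3 (0.00 log units; within the scatter), so this assay does not separate the two nitro compounds. Among these three compounds, then, the gap follows the exchange of nitro for methoxy, while the place of the nitro group on the ring makes no difference that can be read.

Going by these compounds, whether 4-methoxyphenyl would match 3-methoxyphenyl remains open, as does whether an amine, a nitrile or a carboxylic acid on the ring would stand with the nitro compounds. What lies behind the gap between nitro and methoxy also remains open, as no supporting evidence is available to explain it.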